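This account rests on a few compounds, and the source may have more. Where it says the series, first, only, none or still open, it means among the compounds named here.

Of the compounds shown here, two have been measured so far in an ADME assay on Caco-2 cells (Homo sapiens) for permeability, read by LC-MS, with a stated time of 2 h, tested at 3 uM; on this read-out lower numbers stand for lower permeability and higher numbers for higher permeability. Compound 1 `CCN(c1cc2oc(-c3ccc(F)cc3)c(C(=O)NC)c2cc1-c1cc(C)c(OC)c(C(=O)NC2(c3ncccn3)CC2)c1)S(C)(=O)=O` gives 33 nm/s, and compound 2 `CCN(C(=O)OC)c1cc2oc(-c3ccc(F)cc3)c(C(=O)NC)c2cc1-c1ccc(OC)c(C(=O)NC2(c3ncccn3)CC2)c1` gives 24 nm/s. The two numbers lie within the usual scatter of each other, so on the data so far compound 2 cannot be told apart from compound 1 in this assay.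

Compound 3 `CCN(C(=O)N(C)C)c1cc2oc(-c3ccc(F)cc3)c(C(=O)NC)c2cc1-c1ccc(OC)c(C(=O)NC2(c3ncccn3)CC2)c1` has not been measured. It differs from compound 2 in one place: dimethylamino in place of methoxy on a carbonyl carbon. Among the compounds with values here, no measured pair shows this kind of change, so the size of the step is open.

Within the data shown here, with only two nearby numbers to lean on, the expected step from compound 2 to compound 3 in this assay is small, a 1.2-fold lower number from compound 2 to compound 3 (0.08 log units; within the scatter), and is not expected to reach beyond the scatter. Compound 3 is therefore estimated at 20 nm/s, with a likely range from 10 nm/s to 40 nm/s.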

Compound 3, apparent permeability: 20 nm/s
The estimate for compound 3 equals the measured number at the digits printed, within the range that was stated.
By their numbers in this assay, from the lowest: compounds 3, 2 and 1 (each within the scatter of the next).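

Swapping the methoxy group of compound 2 for dimethylamino on a carbonyl carbon gives the first measured step at this place in this assay: a 1.2-fold lower number from compound 2 to compound 3 (0.08 log units; within the scatter). Methoxycarbonyl and dimethylcarbamoyl on this amide-type nitrogen therefore cannot be told apart by this read-out, even though the swap removes an oxygen and brings in a nitrogen and one more carbon. Nothing measured here gives a reason for this result.

This is one replacement at one place on the shared core, so it does not show whether other groups on the same carbonyl carbon would also stay within the scatter of compound 2. A ring amine such as morpholine or pyrrolidine, or a plain methyl group in place of the methoxy, remains an open case.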